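Replacing phenyl with 1-benzofuran-2-yl in compound 2

A few compounds are considered here, and "the series" means these few. Any claim that something is new, unique, unknown or untested is made for them only; others in the source may bear on it.

Of the compounds shown here, two have been read so far in a functional assay on K562 cells (Homo sapiens), read by MTT assay, with a stated time of 72 h; a lower number here means a stronger inhibitor, a higher number a weaker inhibitor. Within the data shown here, compound 1 `COc1ncnc2c1c(-c1cc3ccccc3o1)cn2[C@@H]1O[C@H](CO)[C@@H](O)[C@H]1O` gives 20900 nM, the only actual number in this small set.

Compound 2 `COc1nc(N)nc2c1c(-c1ccccc1)cn2[C@@H]1O[C@H](CO)[C@@H](O)[C@H]1O` gives > 20000 nM in this assay. This value is a limit and not a number, so compound 2 has no exact position on the scale.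

The next step leads to compound 3 `COc1nc(N)nc2c1c(-c1cc3ccccc3o1)cn2[C@@H]1O[C@H](CO)[C@@H](O)[C@H]1O`, which is still unmeasured. Its change from compound 2 is 1-benzofuran-2-yl in place of phenyl on an aromatic carbon, two ring bonds from the ring nitrogen.

Among the measured compounds shown here, no measured step covers this change, so any size given for it remains an expectation. The expected at least 1.6-fold lower number from compound 2 to compound 3 (0.22 log units; that floor lies within the scatter) in this assay is modest and points towards a stronger inhibitor, though it may not clear the scatter. For the measured compounds named here, this expectation rests on compound 1, whose value of 20900 nM is the only number available as a guide.

For compound 3 the estimated value is 12000 nM, with an expected range of 3000 nM to 30000 nM.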

Compound 3, half-maximal inhibitory concentration: 14600 nM
Estimate against measurement, compound 3: 1.2-fold (0.09 log units) below, within the range that was stated.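

In this assay, 1-benzofuran-2-yl in place of phenyl on an aromatic carbon, two ring bonds from the ring nitrogen, can now be read on a core that carries the amino group, and it gives an at least 1.3-fold lower number from compound 2 to compound 3 (0.13 log units; that floor lies within the scatter). This step is a floor and not a full size, and it stays open-ended on one side because compound 2 has only a limit: the limit of > 20000 nM in this assay, at which 1 of the 3 values shown sits.

The second comparison holds 1-benzofuran-2-yl fixed and shows amino in place of hydrogen on an aromatic carbon, with a 1.4-fold lower number from compound 1 to compound 3 (0.16 log units; within the scatter), so this change is not separated from the scatter at this level of the read-out.

The compounds shown leave open whether any group at this aromatic carbon gives a step that clearly exceeds the scatter, and a thiophene ring or a pyridine ring there would test whether the answer depends on the ring that enters. They also leave open how the series responds when the methoxy group on the shared core gives way to a dimethylamino group.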